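Replacing the (2-phenylethenyl)sulfonyl group of compound 2

This account rests on a few compounds, and the source may have more. Where it says the series, first, only, none or still open, it means among the compounds named here.

Compound 1 `C=CS(=O)(=O)N1CCN(c2nc(OC[C@H]3CCCN3C)nc3sc(-c4ccc(OC)nc4)cc23)CC1` gives 3560 nM
Compound 2 `CN1CCN(c2ccc(-c3cc4c(N5CCN(S(=O)(=O)/C=C/c6ccccc6)CC5)ncnc4s3)cc2)CC1` gives 5900 nM

In a functional assay on MDA-MB-231 cells (Homo sapiens) for antiproliferative activity, read by MTT assay, with a stated time of 48 h (a lower number here means a stronger inhibitor, a higher number a weaker inhibitor), compound 2 gives 5900 nM and sits within the usual scatter of compound 1, so these two values cannot be told apart. Compound 3 `CCCNC(=O)N1CCN(c2ncnc3sc(-c4ccc(N5CCN(C)CC5)cc4)cc23)CC1` keeps the rest of compound 2 and changes one place, an amine nitrogen in a ring (propylcarbamoyl in place of (2-phenylethenyl)sulfonyl on an amine nitrogen in a ring). Among the measured compounds shown here, no measured pair shows what this swap does, so no direction can be argued from the data. The expected size is a 1.1-fold higher number from compound 2 to compound 3 (0.04 log units; within the scatter) in this assay, which would be nothing beyond the scatter. The estimate for compound 3 is 6500 nM (expected range 2000 nM to 20000 nM).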

Compound 3, half-maximal inhibitory concentration: 8330 nM
Compound 3: middle estimate off by 1.3-fold (0.11 log units), on the low side, and the stated range covers the measured number.
By their numbers in this assay, from the lowest: compounds 1, 2 and 3 (each within the scatter of the next, the first and the last beyond it).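

The amine nitrogen in a ring carries propylcarbamoyl in place of (2-phenylethenyl)sulfonyl with a 1.4-fold higher number from compound 2 to compound 3 (0.15 log units; within the scatter) in this assay and so the two groups cannot be told apart here. For this pair, the sulfonyl group, the aromatic ring of carbon only and five of the heavy atoms can go without a change beyond the scatter. No measurement here offers an explanation for this result. The compounds shown leave open whether phenylcarbamoyl, which would restore an aromatic ring, or plain methylsulfonyl on this nitrogen would move the number beyond the scatter.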